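The compounds below may be only part of what the source reports. "The series", "measured", "known", "first", "only" and "open" are said of these compounds alone.

Compound 1 `Cc1cccc(S(=O)(=O)NCc2ccc(CNC(=O)c3ccc(CNc4ncccn4)cc3)cc2)c1`: 100 nM
Compound 2 `O=C(NCc1ccc(CNS(=O)(=O)c2cccc(Cl)c2)cc1)c1ccc(CNc2ncccn2)cc1`: 1 nM

In an assay on MDA-MB-231 cells for binding affinity to C-X-C chemokine receptor type 4 (Homo sapiens), read by microscopy, with stated times of 10 min and 30 min (a lower number here means that less compound is needed, a higher number that more compound is needed for the effect), compound 2 gives the lowest of the two numbers; compound 1 gives the other, and the change of a 100-fold lower number from compound 1 to compound 2 (2.00 log units; beyond the scatter) separates them. Compound 3 `O=C(NCc1ccc(CNS(=O)(=O)c2ccc(F)cc2)cc1)c1ccc(CNc2ncccn2)cc1` differs from compound 2 by 4-fluorophenyl in place of 3-chlorophenyl on a sulfonyl sulfur. Among the measured compounds shown here, no measured step covers this exact change, but the step from compound 1 to compound 2 shows that the group on the sulfonyl sulfur moves the number strongly. A somewhat higher number is therefore expected for compound 3, estimated at 10 nM (range 1 nM to 100 nM), a step of a 10-fold higher number from compound 2 to compound 3 (1.00 log units; beyond the scatter).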

Compound 3, effective concentration (reported as EC, without a stated level of effect): > 1000 nM
Compound 3 gave a limit, no number; the forecaster's own chance of this, stated with the estimate: 5%; middle value at least 100-fold (2.00 log units) from the limit.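

Compound 3 gives only a limit of the assay, not a number: the limit of > 1000 nM in this assay, at which 1 of the 3 values shown sits.
The earlier pair showed that a change on the aromatic ring can matter, but here 4-fluorophenyl on the sulfonyl sulfur gives an at least 1000-fold higher number from compound 2 to compound 3 (3.00 log units; beyond the scatter) and also an at least 10-fold higher number from compound 1 to compound 3 (1.00 log units; beyond the scatter). This position therefore tolerates some aryl groups far better than others, and compound 3 sits on the weak side of both earlier compounds.

Two things change at once in this step, the halogen and its place on the ring, so the compounds shown cannot separate them. A 4-chlorophenyl or 3-fluorophenyl group would tell these two apart.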